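The source may report more compounds than this note shows. Statements on the series, on what has been measured and on what is new or still open speak of the compounds shown alone.

In a functional assay (aorta) with Oryctolagus cuniculus as the target (a higher number here means a weaker inhibitor, a lower number a stronger inhibitor), compound 1 `COc1ccc([C@@H]2Cc3c(cccc3C(F)(F)F)N(C[C@@H]3CCCN3)C(=O)[C@@H]2OC(C)=O)cc1` gives 91 nM and compound 2 `COc1ccc([C@@H]2Cc3c(cccc3C(F)(F)F)N(C[C@@H]3CCCN3)C(=O)[C@@H]2O)cc1` gives 95 nM, so the two stand level. Compound 3 `COc1ccc([C@@H]2Cc3c(cccc3C(F)(F)F)N(CC=O)C(=O)[C@@H]2OC(C)=O)cc1` carries formyl in place of pyrrolidin-2-yl on a saturated chain carbon bound to an amide-type nitrogen in a ring. For the measured compounds named here, the only measured step, a 1.0-fold higher number from compound 1 to compound 2 (0.02 log units; within the scatter), concerns the acetyl and does not bear on this change. The expectation therefore rests on the structural change alone: a clearly higher number in this assay, of uncertain size. The expected step is a 33-fold higher number from compound 1 to compound 3 (1.52 log units; beyond the scatter). For compound 3 the estimated value is 3000 nM, with a range of 300 nM to 30000 nM.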

Compound 3, half-maximal inhibitory concentration: > 3000 nM
Compound 3: only a limit was reported (the forecaster's own chance of this, stated with the estimate: 25%); the middle value sits exactly at the limit.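

At the saturated chain carbon bound to an amide-type nitrogen in a ring, formyl in place of pyrrolidin-2-yl gives an at least 32-fold higher number from compound 1 to compound 3 (1.51 log units; beyond the scatter). This position therefore responds strongly to change, whereas the acetyl change, a 1.0-fold higher number from compound 1 to compound 2 (0.02 log units; within the scatter), showed nothing of the kind. Compound 3 is known in this assay only as a limit, which leaves the full size of the step unknown: the limit of > 3000 nM in this assay, at which 1 of the 3 values shown sits.

The change removes the ring and its nitrogen together, and the compounds shown cannot separate the two. An open-chain amine or a piperidine ring at this place would bear on that question.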